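A few compounds are considered here, and "the series" means these few. Any claim that something is new, unique, unknown or untested is made for them only; others in the source may bear on it.

Values in a functional assay on A549 cells (Homo sapiens) for cytotoxicity, read by XTT assay, with a stated time of 72 h; on this read-out higher numbers stand for weaker inhibition and lower numbers for stronger inhibition:

- Compound 1 `CCCCCCCC/C=C\CCCCCCCCOc1cc(O)cc(O)c1C(C)=O`: > 100000 nM
- Compound 2 `CC(C)=CCC/C=C(\C)Cc1c(O)cc(O)c2c(=O)cc(-c3ccccc3)oc12`: 28000 nM
- Compound 3 `CCCCCCCC/C=C\CCCCCCCCOc1cc(O)c(C(C)=O)c(OCCCCCCCC/C=C\CCCCCCCC)c1`: > 100000 nM

Among the measured compounds shown here, compound 2 gives the only real number in this small set, 28000 nM. Compound 1 reports only a limit of the assay, > 100000 nM. Compound 3 likewise reports only a limit, > 100000 nM. The ceiling therefore shapes the whole picture: the limit of > 100000 nM in this assay, at which 2 of the 3 values shown sit.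

Compound 4 `CC(C)=CCC/C=C(\C)Cc1c(OC/C=C(\C)CCC=C(C)C)cc(O)c2c(=O)cc(-c3ccccc3)oc12` is built from compound 2 by one change on an oxygen on an aromatic ring: 3,7-dimethylocta-2,6-dien-1-yl in place of hydrogen on an oxygen on an aromatic ring. In words, a hydroxy becomes (3,7-dimethylocta-2,6-dien-1-yl)oxy. For the measured compounds named here, no pair of measured compounds shows the size of such a change, so any forecast is loose.

The only hint on direction is indirect. Among the measured compounds, a chain on an oxygen on an aromatic ring also occurs in compound 3, which reports the limit > 100000 nM. A modest move toward weaker inhibition is therefore expected, and the result could reach the limit of the assay. The estimated change is a 2.1-fold higher number from compound 2 to compound 4 (0.33 log units; beyond the scatter). Compound 4 is estimated at 60000 nM, with an expected range of 25000 nM to 100000 nM.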

Compound 4, half-maximal inhibitory concentration: > 100000 nM
Compound 4 gave a limit, no number; the forecaster's own chance of this, stated with the estimate: 45%; middle value at least 1.6-fold (0.22 log units) from the limit.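

In this assay compound 4 gives > 100000 nM, which is a limit of the assay and not a number. Even so, this is the first measured pair that shows what happens at this position: putting 3,7-dimethylocta-2,6-dien-1-yl in place of hydrogen on an oxygen on an aromatic ring gives an at least 3.5-fold higher number from compound 2 to compound 4 (0.55 log units; beyond the scatter), so the change weakens inhibition by more than the usual scatter. This figure is only a minimum, and the true size of the step stays unknown because the read-out ends at a ceiling: the limit of > 100000 nM in this assay, at which 3 of the 4 values shown sit.

The compounds shown leave open whether a much smaller group on this oxygen, such as methyl, would keep the number seen for compound 2 or would also weaken inhibition, and so how long a chain this position tolerates. They also leave open whether a chain ending in an amine or a carboxylic acid would behave differently from the 3,7-dimethylocta-2,6-dien-1-yl chain, and whether changing the other hydroxy on the core would have a similar result.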